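Acrylonitrile series: furan-to-chlorophenyl swap on the amide member

The compounds below may be only part of what the source reports. "The series", "measured", "known", "first", "only" and "open" are said of these compounds alone.

Measured so far:
compound 1 `N#C/C(=C\c1ccc(Cl)cc1)C(=O)c1ccc[nH]1`: 35000 nM
compound 2 `COc1ccc(CNC(=O)/C(C#N)=C/c2ccco2)cc1`: 24000 nM

Two compounds carry numbers in a functional assay on A2780 cells (Homo sapiens) for inhibition, read by MTT assay, with a stated time of 72 h; on this read-out lower numbers stand for stronger inhibition of growth and higher numbers for weaker inhibition of growth. Compound 1 `N#C/C(=C\c1ccc(Cl)cc1)C(=O)c1ccc[nH]1` gives 35000 nM in this assay. Compound 2 `COc1ccc(CNC(=O)/C(C#N)=C/c2ccco2)cc1` gives 24000 nM in this assay, the lower of the two numbers, but the gap to compound 1 lies within the scatter of repeated measurements, so no order between them can be read from these two values.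

Compound 3 `COc1ccc(CNC(=O)/C(C#N)=C/c2ccc(Cl)cc2)cc1` has not yet been measured. It differs from compound 2 in one place: 4-chlorophenyl in place of furan-2-yl on a double-bonded chain carbon bound to a double-bonded chain carbon. The same 4-chlorophenyl group sits on the double-bonded chain carbon of compound 1, whose number in this assay is not separated from that of compound 2 beyond the scatter, so the data give no sign that this group by itself moves the read-out much. The step from compound 2 to compound 3 is therefore expected to be small, a 1.0-fold higher number from compound 2 to compound 3 (0.02 log units; within the scatter), in no clear direction beyond the scatter. For compound 3 the estimate in this assay is 25000 nM, with a range from 8000 nM to 70000 nM.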

Compound 3, concentration for 50% growth inhibition: 7000 nM
Estimate against measurement, compound 3: 3.6-fold (0.55 log units) above; the measured number lies below the stated range.
By their numbers in this assay, from the lowest: compound 3; then compounds 2 and 1 (each within the scatter of the next).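

On a double-bonded chain carbon bound to a double-bonded chain carbon, 4-chlorophenyl in place of furan-2-yl gives a 3.4-fold lower number from compound 2 to compound 3 (0.54 log units; beyond the scatter) in this assay, a modest step but one beyond the scatter. Among the compounds shown here, this is the first one-place comparison, and it shows that the read-out responds to the group at this position, which the two earlier values could not show: compound 1 carries the same 4-chlorophenyl group but differs from compound 3 in more than one place, so it offers no matched comparison. No measured property of either group bears on this step, so its cause remains unassigned.

The pair cannot separate the contribution of the chlorine from that of the change of ring, a question that unsubstituted phenyl or 4-methoxyphenyl at the same position would address. Going by these compounds, it also remains open whether the step carries over when the methoxybenzyl group gives way to a plain benzyl group or a longer alkyl chain.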